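A few compounds are considered here, and "the series" means these few. Any claim that something is new, unique, unknown or untested is made for them only; others in the source may bear on it.

Compound 1, `COc1ccccc1NC1=CC(=O)c2c(nc3n2[C@H]2OC[C@@H](O)[C@H]2OC3)C1=O`: 6580 nM
Compound 2, `CCCN(CCC)C1=CC(=O)c2nc3n(c2C1=O)[C@H]1OC[C@@H](O)[C@H]1OC3`: > 16000 nM

Among the measured compounds shown here, in a functional assay on MCF7 cells (Homo sapiens) for inhibition, read by sulforhodamine B assay (on this read-out lower numbers stand for stronger inhibition and higher numbers for weaker inhibition), compound 1 gives 6580 nM, and this is the only number among the two values available. Compound 2 reaches only a limit of the assay in this assay, > 16000 nM. The record for this series contains (the limit of > 16000 nM in this assay, at which 1 of the 2 values shown sits). For the measured compounds named here, no step between two measured compounds with a single difference is available, so the size of any change rests on the structures alone.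

Compound 3, `O=C1C(Nc2cccc(F)c2)=CC(=O)c2c1nc1n2[C@H]2OC[C@@H](O)[C@H]2OC1`, differs from compound 1 in one place: 3-fluorophenyl in place of 2-methoxyphenyl on an amine nitrogen. One aromatic ring on the amine nitrogen is exchanged for another, with the methoxy group gone and a fluorine in its place on the ring. For compound 3 the expected value in this assay is 7000 nM, with a range from 2500 nM to 20000 nM. The step expected a 1.1-fold higher number from compound 1 to compound 3 (0.03 log units; within the scatter) is small, no larger than the usual scatter, in no firm direction.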

Compound 3, half-maximal inhibitory concentration: > 4000 nM
Compound 3: no number, only a limit; the forecaster's own chance of this, stated with the estimate: 20%; the middle value does not contradict the limit.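

In this assay compound 3 gives only a limit of the assay, > 4000 nM and no number, so the step between compound 1 and compound 3 cannot be read. The compounds shown leave open whether 3-fluorophenyl in place of 2-methoxyphenyl on an amine nitrogen changes the read-out at all, and in which direction.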